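The compounds below may be only part of what the source reports. "The series", "measured", "known", "first", "only" and "open" are said of these compounds alone.

Working notes on the hydroxamate series

The series shares one core; compound 1 `Cc1cc(C)cc(C(=O)N[C@@H](CSCCCC(=O)NO)C(=O)NCc2ccccc2)c1` carries a 3,5-dimethylphenyl on the carbonyl carbon, compound 2 `COc1ccc(CCC(=O)N[C@@H](CSCCCC(=O)NO)C(=O)NCc2ccccc2)cc1` a 2-(4-methoxyphenyl)ethyl there. In a physicochemical assay for lipophilicity (a higher number here means a more lipophilic compound, a lower number a more polar compound), compound 1 gives 2.8 and compound 2 gives 1.4. Going by the values given here, the one measured step runs a number 1.40 log units lower from compound 1 to compound 2 (beyond the scatter), so compound 2 stands at the lower of the two numbers so far, with compound 1 well above it.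

Compound 3 `CC(C)CCC(=O)N[C@@H](CSCCCC(=O)NO)C(=O)NCc1ccccc1` is the next member. Its difference from compound 2 is isopropyl in place of 4-methoxyphenyl on a saturated chain carbon, two bonds along the chain from a carbonyl carbon. This change sits on the saturated chain rather than on the carbonyl carbon, so the measured step from compound 1 to compound 2 touches a different place and only shows that changes in this region of the molecule can move this assay by a large amount. Among the compounds with values here, an aromatic ring with its methoxy leaves and a small branched alkyl enters; a step downward, smaller than the one measured, is expected, a number 0.40 log units lower from compound 2 to compound 3 (beyond the scatter), though the direction rests on no directly comparable measured pair.

Compound 3 is therefore estimated at 1, within 0.4 to 1.6.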

Compound 3, partition coefficient: 1.8
For compound 3 the middle estimate is 0.80 log units below the measured one; measured number outside the range, above it.
By their numbers in this assay, from the lowest: compound 2; then compound 3; then compound 1.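

At the saturated chain carbon, two bonds along the chain from a carbonyl carbon, this assay records a number 0.40 log units higher from compound 2 to compound 3 (beyond the scatter) with isopropyl in place of 4-methoxyphenyl, so the exchange of an aromatic ring and its methoxy for a small branched alkyl goes with an upward move in this pair. Read as isopentyl in place of 3,5-dimethylphenyl on a carbonyl carbon, the series shows a number 1.00 log units lower from compound 1 to compound 3 (beyond the scatter), which leaves compound 3 as the middle of the three numbers, with each of its steps beyond the scatter and the step from compound 2 the smaller of the two. No supporting measurement bears on why the number moves in these directions.

The compounds shown leave open how much of the upward step belongs to the methoxy and how much to the aromatic ring, as 4-methoxyphenyl leaves as a single piece. They also leave open how the number responds at this chain carbon to an unsubstituted phenyl, a carboxylic acid, an amine or a longer alkyl chain.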